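Cytotoxicity in liver cells: swapping an aryl amide for a chain

The source may hold more compounds than are shown below. What is called first, only, known or untested is meant among the compounds shown, and "the series" means these compounds.

Measured compounds:
Compound 1 `O=C(Nc1ccc(O)cc1)c1c(NO)cc(-c2ccccc2)oc1=O` gives > 20000 nM in an ADME assay on Huh-7 cells (Homo sapiens) for cytotoxicity, read by a luciferase reporter and WST assay, with a stated time of 3 days; on this read-out higher numbers stand for lower toxicity in this test and lower numbers for higher toxicity in this test; this value is a limit of the assay, not a number.
Compound 2 `Cc1ccc(-c2cc(NO)c(C(=O)NCCO)c(=O)o2)cc1` gives > 20000 nM in this assay; this too is a limit.
Compound 3 `COc1ccc(-c2cc(NO)c(C(=O)NCCO)c(=O)o2)cc1` gives > 20000 nM in this assay; again a limit.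

Compound 1 therefore stands at the limit of the test, together with the two others; all three rest on (the limit of > 20000 nM in this assay, at which 3 of the 3 values shown sit), so none of them shows measurable toxicity here. For the measured compounds named here, the one step that can be compared, a step that the two limits leave unreadable from compound 2 to compound 3, cannot be read because the limit of > 20000 nM in this assay, at which 3 of the 3 values shown sit, holds both of its values at the limit.

Compound 4 `O=C(NCCCO)c1c(NO)cc(-c2ccccc2)oc1=O` differs from compound 1 by 3-hydroxypropyl in place of 4-hydroxyphenyl on an amide-type nitrogen. Going by the values given here, no measured step bears on this change, so the only guide is that every compound on the shared core sits at the limit. Compound 4 is therefore expected to sit at the limit as well, with an estimate of 25000 nM, in the range 12000 nM to 60000 nM; the expected step that the limit leaves unreadable from compound 1 to compound 4 is none beyond the scatter.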

Compound 4, half-maximal cytotoxic concentration: > 20000 nM
Compound 4: no number, only a limit (the forecaster's own chance of this, stated with the estimate: 85%); the middle value lies beyond the limit too.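

The step from compound 1 to compound 4 cannot be read, because both values are limits: the limit of > 20000 nM in this assay, at which 4 of the 4 values shown sit. The compounds shown leave open whether 3-hydroxypropyl in place of 4-hydroxyphenyl on the amide-type nitrogen changes toxicity at all in this assay.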